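Replacing the Carbonyl Substituent on the Shared Core

This account rests on a few compounds, and the source may have more. Where it says the series, first, only, none or still open, it means among the compounds named here.

Compound 1 `Cc1nc(S(C)(=O)=O)ccc1Oc1ncnc(OC2CCN(C(=O)OC(C)(C)C(F)(F)F)CC2)c1F`: 6.53 nM
Compound 2 `Cc1nc(S(C)(=O)=O)ccc1Oc1ncnc(OC2CCN(C(=O)SC3CC3)CC2)c1F`: 24.9 nM

Going by the values given here, in a functional assay on isolated protein for inhibition of Glucose-dependent insulinotropic receptor (Homo sapiens), read by HTRF and cAMP accumulation (on this read-out higher numbers stand for an effect only at larger amounts of compound and lower numbers for an effect already at smaller amounts), compound 2 stands at the highest of the two numbers; the only other measured compound is compound 1, and the step of a 3.8-fold higher number from compound 1 to compound 2 (0.58 log units; beyond the scatter) lies beyond the scatter. Compound 3 `Cc1nc(S(C)(=O)=O)ccc1Oc1ncnc(OC2CCN(C(=O)c3noc(C(C)(C)F)n3)CC2)c1F` differs from compound 2 by a group of 9 heavy atoms (5 carbon, 2 nitrogen, 1 oxygen, 1 fluorine; one five-membered aromatic ring with 3 hetero atoms) in place of a group of 4 heavy atoms (3 carbon, 1 sulfur; one three-membered non-aromatic ring of carbon only), on a carbonyl carbon. That single measured step also alters the group on the carbonyl carbon and was modest, so compound 3 is expected to move back toward compound 1, a step of about a 2.8-fold lower number from compound 2 to compound 3 (0.44 log units; beyond the scatter). The estimate for compound 3 is 9 nM, with a range from 2.5 nM to 35 nM.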

Compound 3, half-maximal effective concentration: 14 nM
For compound 3 the middle estimate is 1.6-fold (0.19 log units) below the measured one, within the range that was stated.
By their numbers in this assay, from the lowest: compound 1; then compounds 3 and 2 (each within the scatter of the next).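

In this assay the step of a 1.8-fold lower number from compound 2 to compound 3 (0.25 log units; within the scatter) shows that this much larger group, carrying a five-membered aromatic ring with 3 hetero atoms, can sit on the carbonyl carbon without a change that can be told from scatter. The step of a 2.1-fold higher number from compound 1 to compound 3 (0.33 log units; beyond the scatter), however, leaves compound 1, whose group has no ring, with the lowest number of the three, since compound 2 also stands beyond the scatter from it. No measurement here bears on the reason for these results.

The compounds shown leave open whether the ring or its fluorine-bearing substituent matters more. They also leave open how an amine or a phenyl ring would read on this carbonyl carbon.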